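The source may hold more compounds than are shown below. What is called first, only, known or untested is meant among the compounds shown, and "the series" means these compounds.

The measured compounds are compound 1 `COC(=O)c1ccc(CN(CCCc2c(N)nc(N)nc2O)c2cc(F)cc(F)c2[N+](=O)[O-])cc1`, compound 2 `CC(C)(C)OC(=O)CCC(Nc1ccc(CN(CCCc2c(N)nc(N)nc2O)c2ccc([N+](=O)[O-])c(F)c2F)cc1)C(=O)OC(C)(C)C` and compound 3 `CC(C)(C)OC(=O)CCC(Nc1ccc(CN(CCCc2c(N)nc(N)nc2O)c2ccc([N+](=O)[O-])c(F)c2[N+](=O)[O-])cc1)C(=O)OC(C)(C)C`. In a functional assay on CCRF-CEM cells (Homo sapiens) for cytotoxicity, in the presence of a further agent that is not named here (a higher number here means a weaker inhibitor, a lower number a stronger inhibitor), compound 1 reaches only > 100000 nM, which is a limit of the assay rather than a number. Compound 2 gives 20000 nM in this assay. Compound 3 gives 4000 nM in this assay.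

Of the two numbers shown, compound 2 holds the higher one; the single measured step that reaches it is a 5.0-fold lower number from compound 2 to compound 3 (0.70 log units; beyond the scatter), a nitro in place of a fluoro on an aromatic carbon. The third value is a limit, (the limit of > 100000 nM in this assay, at which 1 of the 3 values shown sits).

Compound 4 `CC(C)(C)OC(=O)CCC(Nc1ccc(CN(CCCc2c(N)nc(N)nc2O)c2cc(F)c(F)cc2[N+](=O)[O-])cc1)C(=O)OC(C)(C)C` has not yet been measured. It differs from compound 2 as follows: 4,5-difluoro-2-nitrophenyl in place of 2,3-difluoro-4-nitrophenyl on an amine nitrogen. Within the data shown here, this is a rearrangement of the same atoms on the same ring, not the exchange of one group for another seen from compound 2 to compound 3, so that step does not speak to it, and no measured pair tests such a rearrangement. Compound 1 carries a different pattern of nitro and fluorines together with a different ester, and as it differs from compound 2 in two places it is not a step either.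

With nothing to rest on, compound 4 is expected to show a step of no change at the digits printed from compound 2 to compound 4 (within the scatter), none beyond the scatter, with wide uncertainty. Compound 4 is therefore estimated at 20000 nM, between 5000 nM and 80000 nM.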

Compound 4, half-maximal inhibitory concentration: 3100 nM
For compound 4 the middle estimate is 6.5-fold (0.81 log units) above the measured one; measured number below the stated range.
By their numbers in this assay, from the lowest: compounds 4 and 3 (each within the scatter of the next); then compound 2. At a limit, above all of these: compound 1.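

Rearranging the same atoms on the aromatic ring attached to the amine nitrogen is enough to change the result in this assay: 4,5-difluoro-2-nitrophenyl in place of 2,3-difluoro-4-nitrophenyl gives a 6.5-fold lower number from compound 2 to compound 4 (0.81 log units; beyond the scatter). The earlier compounds shown here showed only the exchange of one group for another, a 5.0-fold lower number from compound 2 to compound 3 (0.70 log units; beyond the scatter), so the substitution pattern of this ring now counts as a variable in its own right, since the group that leaves and the group that enters match in every count computed for them, and both single changes from compound 2 lower the number. Nothing measured here accounts for the step from the 2,3-difluoro-4-nitrophenyl group to its rearranged form.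

Compound 4 moves the nitro group and the fluorines together, so the compounds shown leave open whether the step follows the nitro group, the fluorines or both, and whether a nitrile or an amine in place of that nitro group would keep it. They also leave open whether the same rearrangement would give a similar step with a free carboxylic acid in place of the tert-butyl esters.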